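The source may report more compounds than this note shows. Statements on the series, on what has been measured and on what is new or still open speak of the compounds shown alone.

Of the compounds shown here, three sharing one core have been measured in a functional assay on cells for positive allosteric modulation of G-protein coupled receptor 68 (Homo sapiens), read by a luciferase reporter and cAMP accumulation, with a stated time of 30 min, at pH 6.8 and pH 8.3, in the presence of a further agent that is not named here; a higher number here means a more potent compound, by a factor of ten per unit of this negative logarithm, a lower number a less potent compound. Compound 1 `Nc1nc(NCc2ccc(F)cc2)nc(-c2ccccc2CO)n1` gives 3.97. Compound 2 `Nc1nc(NCc2ccccc2Cl)nc(-c2ccccc2CO)n1` gives 5.07. Compound 3 `Nc1nc(NCCCc2ccccc2)nc(-c2ccccc2CO)n1` gives 5.22, the highest of the three numbers, though its gap to compound 2 lies within the scatter, so the two cannot be ranked. The steps were a number 1.10 log units higher from compound 1 to compound 2 (beyond the scatter) and a number 1.25 log units higher from compound 1 to compound 3 (beyond the scatter), both large, while a number 0.15 log units higher from compound 2 to compound 3 (within the scatter) was within the scatter. Within the data shown here, compound 4 `Nc1nc(NCCCCc2ccccc2)nc(-c2ccccc2CO)n1` differs from compound 3 by benzyl in place of phenyl on a saturated chain carbon, three bonds along the chain from a nitrogen on an aromatic ring, a change that only lengthens the chain, for which no measured step is a direct guide. The nearest comparison, the small step from compound 2 to compound 3, suggests no move beyond the scatter, so compound 4 is expected to give about 5.2, with a range from 4.6 to 5.8, an estimated step of a number 0.02 log units lower from compound 3 to compound 4 (within the scatter).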

Compound 4, negative logarithm of the antagonist equilibrium constant: 5.52
Compound 4: middle estimate off by 0.32 log units, on the low side; low and high end bracket the measured number.
By their numbers in this assay, from the lowest: compound 1; then compounds 2, 3 and 4 (each within the scatter of the next, the first and the last beyond it).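

Lengthening the chain, with benzyl in place of phenyl at this position, gives a number 0.30 log units higher from compound 3 to compound 4 (within the scatter) in this assay. The two compounds therefore cannot be ranked, but the longer chain is accepted here without any loss that stands out from the scatter. Nothing available explains this result. The compounds shown leave open whether a still longer chain would hold this level of potency, or whether it would fall away. They also leave open what an amine or a carboxylic acid at the end of the chain would do.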